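From Compound 2 to Compound 4 at the Limit

The source may hold more compounds than are shown below. What is called first, only, known or untested is meant among the compounds shown, and "the series" means these compounds.

Of the compounds shown here, three have been tested in an ADME assay on HEK293 cells (Homo sapiens) for cytotoxicity, with a stated time of 72 h (a lower number here means that less compound is needed, a higher number that more compound is needed for the effect), so far, and none of them has yet given a number. Compound 1 `C=C[C@@](C)(/C=C/c1ccc(OS(=O)(=O)c2ccc(C)cc2)cc1)CCC=C(C)C` records > 36600 nM as a limit and not a measured value. Compound 3 `C=C[C@@](C)(/C=C/c1ccc(O)cc1)CC/C=C/C(=O)OCc1ccccc1` records > 36600 nM as a limit too. Compound 2 `C=C[C@@](C)(/C=C/c1ccc(O)cc1)CCCO` records > 36600 nM as a limit as well, so its place is known only as a limit and cannot be ranked against the other two. Among the compounds with values here, the whole record in this assay comes down to the limit of > 36600 nM in this assay, at which 3 of the 3 values shown sit, and offers no measured step.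

Compound 4 `C=C[C@@](C)(/C=C/c1ccc(O)cc1)CC/C=C(\C)CO` has yet to be measured. Its difference from compound 2 lies in the chain: 2-(hydroxymethyl)prop-1-en-1-yl in place of hydroxymethyl on a saturated chain carbon, three bonds along the chain from two double-bonded chain carbons and so 2-(hydroxymethyl)prop-1-en-1-yl stands in place of hydroxymethyl on a saturated chain carbon, three bonds along the chain from two double-bonded chain carbons. Within the data shown here, no pair of measured compounds differs in one place only, so the expectation rests on the shared limit alone. An estimated step of a number no higher from compound 2 to compound 4 (the limit leaves the size open) is expected, in no set direction and not beyond the scatter. Compound 4 is estimated at 36600 nM with an expected range from 18000 nM to 73000 nM and will most likely be reported as a limit again.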

Compound 4, half-maximal effective concentration: > 36600 nM
Compound 4: a limit, no number (the forecaster's own chance of this, stated with the estimate: 85%); the middle value sits exactly at the limit.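

In this assay compound 2 and compound 4 both stand only as limits, so no step can be read between them: the limit of > 36600 nM in this assay, at which 4 of the 4 values shown sit.

The compounds shown leave open what concentration of any of them would give the half-maximal effect, and whether 2-(hydroxymethyl)prop-1-en-1-yl in place of hydroxymethyl changes that concentration at all.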